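Swapping the side-chain ring: from thiophene toward pyrazine

A few compounds are considered here, and "the series" means these few. Any claim that something is new, unique, unknown or untested is made for them only; others in the source may bear on it.

Measured compounds:
compound 1, `Nc1nc(NCc2cccs2)nc2sc(-c3ccco3)nc12`: in a functional assay on CHO cells for agonist activity at adenosine receptor A2b (Homo sapiens), read by scintillation counting and cAMP accumulation, with a stated time of 150 min, in the presence of a further agent that is not named here (on this read-out lower numbers stand for stronger inhibition and higher numbers for weaker inhibition), compound 1 gives 75 nM
compound 2, `Nc1nc(NCc2ccncc2)nc2sc(-c3ccco3)nc12`: in this assay compound 2 gives 33 nM
compound 3, `Nc1nc(NCc2ccsc2)nc2sc(-c3ccco3)nc12`: in this assay compound 3 gives 8.96 nM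

All three compounds share the same core and differ only in the aromatic ring that sits on a saturated chain carbon bound to a nitrogen on an aromatic ring. Compound 3 carries the lowest number of the three, and both gaps to it lie beyond the scatter: an 8.4-fold lower number from compound 1 to compound 3 (0.92 log units; beyond the scatter) and a 3.7-fold lower number from compound 2 to compound 3 (0.57 log units; beyond the scatter). Between the other two, a 2.3-fold lower number from compound 1 to compound 2 (0.36 log units; beyond the scatter).

Compound 4, `Nc1nc(NCc2cnccn2)nc2sc(-c3ccco3)nc12`, is not yet measured. It differs from compound 3 in a single place: pyrazin-2-yl in place of thiophen-3-yl on a saturated chain carbon bound to a nitrogen on an aromatic ring. For the measured compounds named here, no measured step introduces a pyrazin-2-yl group, so the nearest guide is the step between a six-membered ring holding one nitrogen and the thiophen-3-yl ring, a 3.7-fold lower number from compound 2 to compound 3 (0.57 log units; beyond the scatter). The change from compound 3 to compound 4 runs the opposite way, from the five-membered sulfur ring back to a six-membered ring, now holding two nitrogens, so a modest rise in number, beyond the scatter and of roughly the size seen in that step, is expected.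

Compound 4 is therefore estimated to give 30 nM in this assay, with a range from 10 nM to 100 nM, which corresponds to an expected step of a 3.3-fold higher number from compound 3 to compound 4 (0.52 log units; beyond the scatter).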

Compound 4, half-maximal inhibitory concentration: 13.2 nM
Estimate against measurement, compound 4: 2.3-fold (0.36 log units) above; low and high end bracket the measured number.
By their numbers in this assay, from the lowest: compounds 3 and 4 (each within the scatter of the next); then compound 2; then compound 1.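

In this assay the six-membered pyrazin-2-yl ring holds up as well as the five-membered thiophen-3-yl ring, with a 1.5-fold higher number from compound 3 to compound 4 (0.17 log units; within the scatter), so at this position a change in ring size and a second ring nitrogen together leave the number within the scatter. Ring size alone therefore does not sort these compounds: two six-membered rings part with a 2.5-fold lower number from compound 2 to compound 4 (0.40 log units; beyond the scatter), and two five-membered rings also part with an 8.4-fold lower number from compound 1 to compound 3 (0.92 log units; beyond the scatter), while the pyrazin-2-yl ring also stands clear of the thiophen-2-yl ring, with a 5.7-fold lower number from compound 1 to compound 4 (0.75 log units; beyond the scatter). No separate measurement is available to explain why these rings rank as they do.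

The compounds shown leave open whether the same tolerance extends to other six-membered rings with two nitrogens, such as pyrimidin-2-yl, or to a pyrazin-2-yl ring carrying a methyl group or an amine. They also leave open what happens when a longer chain replaces the single saturated carbon that joins the ring to the nitrogen on the shared core.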